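Compound 3: A Step Starting From a Limit

This account rests on a few compounds, and the source may have more. Where it says the series, first, only, none or still open, it means among the compounds named here.

Compound 1 `Cc1ccc(-c2nc3ccccc3s2)cc1NC(=O)c1cc([N+](=O)[O-])c(N2CCC(C(=O)O)CC2)cc1Cl`: > 25000 nM (a limit)
Compound 2 `COc1ccc(-c2nc3ccccc3s2)cc1NC(=O)c1cc([N+](=O)[O-])ccc1Cl`: > 25000 nM (a limit)

In an ADME assay on Raji cells (Homo sapiens) for cytotoxicity, with a stated time of 72 h (a lower number here means that less compound is needed, a higher number that more compound is needed for the effect), compound 2 gives > 25000 nM, which is a limit and not a number. Compound 1 gives > 25000 nM, which is also a limit. The whole record so far is the limit of > 25000 nM in this assay, at which 2 of the 2 values shown sit.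

Compound 3 `COc1ccc(-c2nc3ccccc3s2)cc1NC(=O)c1cc([N+](=O)[O-])c(N2CCC(C(=O)O)CC2)cc1Cl` differs from compound 2 in one place: 4-carboxypiperidin-1-yl in place of hydrogen on an aromatic carbon. In short, 4-carboxypiperidin-1-yl stands in place of hydrogen on an aromatic carbon, ortho to a nitro group and meta to a chloro group.

For the measured compounds named here, no measured step is available to size this change, as neither measured compound gives a number. In this assay the expectation is therefore no step beyond the scatter, in either direction, and compound 3 will probably also read as a limit. That expectation rests on compound 2, whose > 25000 nM is a limit. It rests equally on compound 1, whose > 25000 nM is a limit too. The expected change is a number no higher from compound 2 to compound 3 (the limit leaves the size open). For compound 3 the estimated value is 25000 nM, with an expected range of 12000 nM to 50000 nM.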

Compound 3, half-maximal effective concentration: > 25000 nM
Compound 3 was reported as a limit; the forecaster's own chance of this, stated with the estimate: 85%; the middle value sits exactly at the limit.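

In this assay compound 3 gives > 25000 nM, which is a limit and not a number. No step can be read from compound 2 to compound 3 or from compound 1 to compound 3, and the record now stands as follows: the limit of > 25000 nM in this assay, at which 3 of the 3 values shown sit.

The compounds shown leave open how large either change is, and whether any of these three compounds would give a number at all.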